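This account rests on a few compounds, and the source may have more. Where it says the series, first, only, none or still open, it means among the compounds named here.

Working notes on the series. Within the data shown here, in a functional assay on KYSE-450 cells (Homo sapiens) for inhibition, read by CCK-8 assay, with a stated time of 48 h (on this read-out lower numbers stand for stronger inhibition and higher numbers for weaker inhibition), compound 1 (`COc1cc(N(Cc2ccc(Cl)cc2)C(=O)CSC(=S)N2CCN(C(=O)OC(C)(C)C)CC2)cc(OC)c1OC`) gives 11900 nM as its value, while compound 2 (`COc1ccc(CN(C(=O)CSC(=S)N2CCN(C(=O)OC(C)(C)C)CC2)c2cc(OC)c(OC)c(OC)c2)cc1N=[N+]=[N-]`) gives 840 nM and holds the lower of the two numbers so far. Compound 3 (`COc1ccc(CN(C(=O)CSC(=S)N2CCN(C(=O)OC(C)(C)C)CC2)c2cc(OC)c(OC)c(OC)c2)cc1O`) keeps the rest of compound 2 and has hydroxy in place of azido on an aromatic carbon, ortho to a methoxy group and meta to a large group (hydroxy in place of azido on an aromatic carbon). Among the measured compounds shown here, only one measured step bears on this change: the large step of a 14-fold lower number from compound 1 to compound 2 (1.15 log units; beyond the scatter) when 3-azido-4-methoxyphenyl replaces 4-chlorophenyl. That step swaps the whole aryl group, so it shows that this part of the structure can move the number substantially. For the measured compounds named here, it does not separate azido from methoxy, and no measured pair isolates the azido group. Going by these compounds, compound 3 retains the methoxy group, so no step beyond the scatter is the central expectation in this assay and no direction is firmly expected, though a wide range remains open. The estimated change is a 1.2-fold lower number from compound 2 to compound 3 (0.08 log units; within the scatter) on this reasoning. The expected value for compound 3 is 700 nM within an estimated range of 120 nM to 4000 nM in this assay.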

Compound 3, half-maximal inhibitory concentration: 76 nM
The estimate for compound 3 lay 9.2-fold (0.96 log units) above the measured number, and the stated range ends above it.
By their numbers in this assay, from the lowest: compound 3; then compound 2; then compound 1.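

In this assay, this position on the aromatic carbon, ortho to a methoxy group, moves the number strongly on its own: with the methoxy group and the rest of the structure held constant, hydroxy in place of azido gives an 11-fold lower number from compound 2 to compound 3 (1.04 log units; beyond the scatter) in a single-group change. The step from compound 1 to compound 2 could not show this, as it exchanged the whole aryl group; the corresponding exchange of 4-chlorophenyl for 3-hydroxy-4-methoxyphenyl now gives a 160-fold lower number from compound 1 to compound 3 (2.19 log units; beyond the scatter) and widens the span seen for this part of the structure. Nothing available here accounts for the size of the change, although the counts do show that hydroxy brings a hydrogen-bond donor and azido does not.

Going by these compounds, whether that donor is what matters remains open, and an amine or a second methoxy group at the same place would bear directly on the question. Also open is how much the methoxy group shared by compound 2 and compound 3 contributes, since the steps shown change only the aryl group and leave the remainder of the shared core untouched.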